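Swapping the aryl group of compound 2

The compounds below may be only part of what the source reports. "The series", "measured", "known", "first", "only" and "open" are said of these compounds alone.

In a functional assay on DU-145 cells (Homo sapiens) for inhibition, read by trypan blue exclusion, with a stated time of 96 h (on this read-out higher numbers stand for weaker inhibition of growth and lower numbers for stronger inhibition of growth), compound 1 (`O=C(/C(=C\c1ccc(Cl)cc1)SCc1ccccc1Cl)c1ccc(Cl)cc1`) gives 12000 nM and compound 2 (`Cc1ccc(CS/C(=C/c2cc([N+](=O)[O-])ccc2F)C(=O)c2ccc(Cl)cc2)cc1`) gives 1000 nM as the lower of the two numbers, a gap beyond the usual scatter. Compound 3 (`Cc1ccc(CS/C(=C/c2ccc(Cl)cc2)C(=O)c2ccc(Cl)cc2)cc1`) has not yet been measured. It has 4-chlorophenyl in place of 2-fluoro-5-nitrophenyl on a double-bonded chain carbon bound to a double-bonded chain carbon. Among the measured compounds shown here, no measured pair isolates this change, so the expectation is tentative. For the measured compounds named here, compound 1 carries 4-chlorophenyl at that same place and gives 12000 nM as the only guide, which points to weaker inhibition of growth than in compound 2. The expected move in this assay is an upward one beyond the scatter, estimated as a 5.0-fold higher number from compound 2 to compound 3 (0.70 log units; beyond the scatter) for now. For compound 3 the estimated value is 5000 nM (expected range 1500 nM to 15000 nM).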

Compound 3, concentration for 50% growth inhibition: 10000 nM
Estimate against measurement, compound 3: 2.0-fold (0.30 log units) below, within the range that was stated.
By their numbers in this assay, from the lowest: compound 2; then compounds 3 and 1 (each within the scatter of the next).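

In this assay, the exchange of 2-fluoro-5-nitrophenyl for 4-chlorophenyl on a double-bonded chain carbon bound to a double-bonded chain carbon can now be read on its own, and it gives a 10-fold higher number from compound 2 to compound 3 (1.00 log units; beyond the scatter) with the weaker inhibition of growth on the 4-chlorophenyl side. With 4-chlorophenyl held at that place, 4-methylphenyl in place of 2-chlorophenyl on a saturated chain carbon bound to a sulfur gives a 1.2-fold lower number from compound 1 to compound 3 (0.08 log units; within the scatter) and so does not separate the two compounds. Nothing measured here accounts for either step.

The compounds shown leave open whether the fluorine or the nitro group of 2-fluoro-5-nitrophenyl carries the difference. They also leave open how a phenyl bearing an amine or a carboxylic acid would read at this place.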